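The source may hold more compounds than are shown below. What is called first, only, known or untested is meant among the compounds shown, and "the series" means these compounds.

Measured so far:
- compound 1, `CN(C)CCN(CCN(C)C)c1ccc(C(=O)N2CCc3ccc(OS(N)(=O)=O)cc3C2)cc1`, in an assay on HEK293 cells for inhibition of Steryl-sulfatase (Homo sapiens), tested at 0.1 uM (a higher number here means a stronger effect of the compound at the concentration tested, a lower number a weaker effect), gives 3.8%
- compound 2, `CN(C)CCCN(Cc1ccccc1)c1cccc(C(=O)N2CCc3ccc(OS(N)(=O)=O)cc3C2)c1`, in this assay gives 23.8%
- compound 3, `CCN(Cc1ccccc1)Cc1ccc(S(=O)(=O)N2CCc3ccc(OS(N)(=O)=O)cc3C2)cc1`, in this assay gives 10%

All three compounds share the same core, and each carries a different amine-bearing group on the aryl ring attached to it. Compound 1 stands lowest of the three numbers in this assay. Its gap to compound 3 lies within the usual scatter, so the two cannot be told apart; its gap to compound 2 lies beyond the scatter, and compound 2 is the only one of the three that clearly rises above it.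

Compound 4, `CCN(Cc1ccccc1)c1ccc(C(=O)N2CCc3ccc(OS(N)(=O)=O)cc3C2)cc1`, has not yet been measured in this assay. It differs from compound 1 in one place: benzyl(ethyl)amino in place of bis(2-(dimethylamino)ethyl)amino on an aromatic carbon. The same benzyl(ethyl)amino group is found in compound 3, though there it sits on a different linker, and compound 2 also carries a benzyl on its amine. Among the compounds with values here, no measured pair shows this exact change, so any expectation rests on those neighbours. The step from compound 1 to compound 4 is expected to be a modest rise, a number 10.2 percentage points higher from compound 1 to compound 4 (beyond the scatter), possibly no larger than the scatter. Compound 4 is therefore estimated at 14%, between 3% and 32%.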

Compound 4, a percentage reported as inhibition, at one concentration (the size of the read-out at that concentration, not a potency): 66.9%
The estimate for compound 4 lay 52.9 percentage points below the measured number, outside the stated range (above it).
By their numbers in this assay, from the lowest: compounds 1 and 3 (each within the scatter of the next); then compound 2; then compound 4.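

Measured in this assay with the shared core unchanged, swapping bis(2-(dimethylamino)ethyl)amino for benzyl(ethyl)amino on this aromatic carbon, para to a large group, gives the step of a number 63.1 percentage points higher from compound 1 to compound 4 (beyond the scatter) and shows that the group at this place can strongly change the read-out. Within the data shown here, compounds 2 and 3 differ from compound 1 in more than one place, so this is the first reading of a change at this place alone. The swap brings in a six-membered aromatic ring of carbon only and removes nitrogen atoms together, and no measurement at hand explains the rise.

Open, as far as these compounds go, is whether the benzyl or the ethyl part of the new group matters more. A simple ethylamino group or a dibenzylamino group at the same place would help separate the two.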